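Adding a Second Chloro to a Benzoxazole Sulfonamide

The source may report more compounds than this note shows. Statements on the series, on what has been measured and on what is new or still open speak of the compounds shown alone.

In an ADME assay on HEK293 cells (Homo sapiens) for cytotoxicity, read by resazurin assay, with a stated time of 48 h (on this read-out higher numbers stand for lower toxicity in this test and lower numbers for higher toxicity in this test), compound 1 `O=S(=O)(Nc1ccc2oc(-c3ccccc3)nc2c1)c1ccc(Cl)cc1` gives 65000 nM. Compound 2 `COc1ccccc1S(=O)(=O)Nc1ccc(-c2nc3ccccc3o2)cc1` gives only a limit of this assay, > 100000 nM.

Compound 1 thus holds the only number shown here; the other value sits at the limit of > 100000 nM in this assay, at which 1 of the 2 values shown sits. Compound 3 `O=S(=O)(Nc1ccc2oc(-c3ccccc3)nc2c1)c1ccc(Cl)c(Cl)c1` differs from compound 1 by chloro in place of hydrogen on an aromatic carbon. Among the measured compounds shown here, no measured pair shows what this change does, so any expectation rests on compound 1 alone. The step from compound 1 to compound 3 is expected to be small, at most the size of ordinary scatter, and if anything toward a lower number, a 1.3-fold lower number from compound 1 to compound 3 (0.11 log units; within the scatter). Compound 3 is therefore estimated at 50000 nM, within 20000 nM to 100000 nM.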

Compound 3, half-maximal cytotoxic concentration: 71000 nM
The estimate for compound 3 lay 1.4-fold (0.15 log units) below the measured number; low and high end bracket the measured number.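

Turning 4-chlorophenyl into 3,4-dichlorophenyl gives, in this assay, a 1.1-fold higher number from compound 1 to compound 3 (0.04 log units; within the scatter). This first measured step at this position shows that it takes a second chloro with no shift beyond ordinary scatter. Nothing measured here gives a reason for this result. Still open, as far as these compounds go, is whether an amine or a carboxylic acid on this same aromatic carbon, ortho to the chloro group, would also leave the number in place. One step on one core also cannot show whether this chloro swap would behave the same way on other compounds.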